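The source may report more compounds than this note shows. Statements on the series, on what has been measured and on what is new or still open speak of the compounds shown alone.

Two measured compounds share one core. Compound 1 `Cc1ccc(C(=O)c2ccc(C(=O)c3ccc(C(=O)O)cc3)cc2)cc1` gives 10 nM in an assay on CHO cells for inhibition of 3-oxo-5-alpha-steroid 4-dehydrogenase 2 (Homo sapiens); on this read-out higher numbers stand for weaker inhibition and lower numbers for stronger inhibition. Compound 2 `O=C(O)c1ccc(C(=O)c2ccc(C(=O)c3ccc(C(F)(F)F)cc3)cc2)cc1` gives 30 nM in this assay, the highest of the two numbers, and the step of a 3.0-fold higher number from compound 1 to compound 2 (0.48 log units; beyond the scatter) lies beyond the scatter. Compound 3 `O=C(O)c1ccc(C(=O)c2ccc(C(=O)c3ccc([N+](=O)[O-])cc3)cc2)cc1` differs from compound 2 by nitro in place of trifluoromethyl on an aromatic carbon. No measured step exchanges trifluoromethyl for nitro; the only step shown, a 3.0-fold higher number from compound 1 to compound 2 (0.48 log units; beyond the scatter), is modest. Among the measured compounds shown here, with no closer precedent, the expected step of no change at the digits printed from compound 2 to compound 3 (within the scatter) stays within the scatter. Compound 3 is therefore expected to give 30 nM, within 10 nM to 90 nM.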

Compound 3, inhibition constant: 100 nM
For compound 3 the middle estimate is 3.3-fold (0.52 log units) below the measured one; the whole stated range lies below it.
By their numbers in this assay, from the lowest: compound 1; then compound 2; then compound 3.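

The group on this aromatic carbon, para to a large group, sets the read-out in this assay over a wider span than the first pair showed: nitro in place of trifluoromethyl gives a 3.3-fold higher number from compound 2 to compound 3 (0.52 log units; beyond the scatter) and nitro in place of methyl gives a 10-fold higher number from compound 1 to compound 3 (1.00 log units; beyond the scatter) in this series. Among these three groups, methyl gives the lowest number and nitro the highest, with both new steps beyond the scatter. No data at hand account for this order.

On these data alone, whether an amine, a chlorine or a methoxy group here would fall within this span remains open. So does whether any group at this position would give a lower number than methyl.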